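Replacing the dichlorophenyl on the pyrazole nitrogen with pyridin-2-yl

The compounds below may be only part of what the source reports. "The series", "measured", "known", "first", "only" and "open" are said of these compounds alone.

The measured compounds and their values:
compound 1, `O=C(O)c1cc(-c2ccc(-c3ccc(Cl)cc3Cl)cc2)n(Cc2cccnc2)n1`, > 100000 nM
compound 2, `O=C(O)c1cc(-c2ccc(-c3ccc(F)c(Cl)c3)cc2)n(-c2ccc(Cl)cc2Cl)n1`, 20900 nM
compound 3, `O=C(O)c1cc(-c2ccc(-c3ccc(Cl)cc3Cl)cc2)n(-c2ccc(Cl)cc2Cl)n1`, 11900 nM

Three compounds sharing one core have been examined in an assay on isolated protein for inhibition of methionine--tRNA ligase, cytoplasmic (Homo sapiens); a higher number here means a weaker inhibitor, a lower number a stronger inhibitor. Compound 1 has only a limit of this assay, > 100000 nM, and no number. Compound 3 gives the lowest of the two numbers, and compound 2 gives 20900 nM, which sits within the scatter of it. Among the measured compounds shown here, the one change that clearly mattered is an at least 8.4-fold lower number from compound 1 to compound 3 (0.92 log units; beyond the scatter), where the group on the aromatic nitrogen was exchanged; the limit of > 100000 nM in this assay, at which 1 of the 3 values shown sits, means that the true size of that step is unknown. The exchange on the aromatic carbon, a 1.8-fold lower number from compound 2 to compound 3 (0.24 log units; within the scatter), changed nothing beyond the scatter.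

Compound 4, `O=C(O)c1cc(-c2ccc(-c3ccc(Cl)cc3Cl)cc2)n(-c2ccccn2)n1`, has not been measured. It differs from compound 3 by pyridin-2-yl in place of 2,4-dichlorophenyl on an aromatic nitrogen. For the measured compounds named here, the only measured step touching this position runs the other way: a pyridine-containing group gave way to 2,4-dichlorophenyl and the number fell, in compound 1 to compound 3. Returning a pyridine ring to this nitrogen is therefore expected to raise the number, though compound 1 carried a methylene-linked pyridine, not a directly bound one, so the size is uncertain. Compound 4 is expected to give 50000 nM, between 15000 nM and 150000 nM, a step of a 4.2-fold higher number from compound 3 to compound 4 (0.62 log units; beyond the scatter) in this assay, with a real chance that only a limit is reported.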

Compound 4, half-maximal inhibitory concentration: > 100000 nM
Compound 4: only a limit was reported; the forecaster's own chance of this, stated with the estimate: 40%; middle value at least 2.0-fold (0.30 log units) away from the limit.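

The exchange on this nitrogen now has a second reading: with pyridin-2-yl bound directly to the ring nitrogen and no methylene link, the change still gives an at least 8.4-fold higher number from compound 3 to compound 4 (0.92 log units; beyond the scatter) in this assay, so the loss seen with compound 1 does not depend on that link. Compound 4 has only a limit, > 100000 nM, and not a number, so the printed step gives a minimum size and not the true one. The step between compound 1 and compound 4 cannot be read, and pyridin-2-yl and (pyridin-3-yl)methyl therefore cannot be ranked against each other: the limit of > 100000 nM in this assay, at which 2 of the 4 values shown sit.

The compounds shown leave open whether the loss follows the ring nitrogen of the pyridine or the departure of the two chlorines, a question that an unsubstituted phenyl or a 4-chlorophenyl on this nitrogen would address. They also leave open whether the carboxylic acid is needed for the activity of compound 3, at 11900 nM, since every compound shown keeps it and none carries an ester or amide in its place.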